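Ethyl for Hydrogen at the Ring Nitrogen of Compound 3

This account rests on a few compounds, and the source may have more. Where it says the series, first, only, none or still open, it means among the compounds named here.

Compound 3 `O=C(NCc1ccccc1)c1nc(Cc2ccccc2C(F)(F)F)[nH]c(=O)c1O` stands at the edge of what an ADME assay on HepG2 cells (Homo sapiens) for cytotoxicity, in the presence of a further agent that is not named here (a lower number here means a stronger inhibitor, a higher number a weaker inhibitor), reports. In this assay compound 3 gives > 100000 nM, which is a limit of the assay and not a number. Its two relatives share that position. Compound 2 `Cn1c(Cc2ccccc2C(F)(F)F)nc(C(=O)NCc2ccccc2)c(O)c1=O` gives > 100000 nM in this assay, again a limit. Compound 1 `Cn1c(Cc2ccccc2C(F)(F)F)nc(C(=O)CCc2ccccc2)c(O)c1=O` gives > 100000 nM in this assay, also a limit. Hence the step that the two limits leave unreadable from compound 1 to compound 2 and the step that the two limits leave unreadable from compound 2 to compound 3 are both unreadable; the only thing the three measurements share is the limit of > 100000 nM in this assay, at which 3 of the 3 values shown sit.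

Compound 4 `CCn1c(Cc2ccccc2C(F)(F)F)nc(C(=O)NCc2ccccc2)c(O)c1=O` differs from compound 3 by ethyl in place of hydrogen on an aromatic nitrogen. The measured step that comes closest is a step that the two limits leave unreadable from compound 2 to compound 3, which exchanged methyl for hydrogen at the same aromatic nitrogen and left both ends at the limit. Compound 2, which carries methyl at that nitrogen, gives > 100000 nM, a limit. Nothing among these three compounds suggests that an ethyl there would move the read-out into the measurable range. The expected step that the limit leaves unreadable from compound 3 to compound 4 is therefore none beyond the scatter. Compound 4 is expected to give 200000 nM, within a range of 50000 nM to 1000000 nM, and most likely to be reported again only as a limit.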

Compound 4, half-maximal inhibitory concentration: > 100000 nM
Compound 4: no number, only a limit (the forecaster's own chance of this, stated with the estimate: 85%); the middle value lies beyond the limit too.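

In this assay compound 4 gives > 100000 nM, a limit of the assay and not a number, so neither the step from compound 3 nor the step from compound 2 can be read, and all the compounds stand at one place: the limit of > 100000 nM in this assay, at which 4 of the 4 values shown sit.

The compounds shown leave open how far apart they truly lie, and whether any change to the shared core would give a measurable value in this assay.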